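The compounds below may be only part of what the source reports. "The series", "measured", "known", "first", "only" and "open" are said of these compounds alone.

Measured so far in an assay on HEK293 cells for antagonist activity at transient receptor potential cation channel subfamily V member 2 (Rattus norvegicus), read by fluorescence and calcium flux, with a stated time of 5 min; on this read-out lower numbers stand for stronger inhibition and higher numbers for weaker inhibition:

Compound 1 `CCCCCC[C@@H](O)C/C=C\CCCCCCCCSCCC(=O)NCc1ccc(O)c(OC)c1` gives > 10000 nM, which is a limit of this assay rather than a number.
Compound 2 `CCCCCCCC/C=C\CCCCCCCC[Se]CCC(=O)NCc1ccc(O)c(OC)c1` gives 1800 nM.
Compound 3 `CCCCCCCC/C=C\CCCCCCCCSCCC(=O)NCc1ccc(O)c(OC)c1` gives 2500 nM.

Compound 2 and compound 3 differ in their cores; that difference is not broken down here. The two numbers of compound 2 and compound 3 lie within the usual scatter of each other, so no order between them is drawn.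

Compound 1 is the hydroxylated counterpart of compound 3. The change is hydroxy in place of hydrogen on a saturated chain carbon bound to two saturated chain carbons, and it produced an at least 4.0-fold higher number from compound 3 to compound 1 (0.60 log units; beyond the scatter). The size of that step is bounded only on one side, because the limit of > 10000 nM in this assay, at which 1 of the 3 values shown sits, is where compound 1 sits.

Compound 4 `CCCCCC[C@@H](O)C/C=C\CCCCCCCC[Se]CCC(=O)NCc1ccc(O)c(OC)c1` is not yet measured in this assay. It stands to compound 2 as compound 1 stands to compound 3: the change is hydroxy in place of hydrogen on a saturated chain carbon bound to two saturated chain carbons, the same kind of change on the same place in the chain, here applied to the core of compound 2 instead of the core of compound 3.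

Among the measured compounds shown here, the single measured instance of this change weakened inhibition by at least the step seen from compound 3 to compound 1. Carrying the same step over from compound 2, a weakening of a like size is expected, a 5.0-fold higher number from compound 2 to compound 4 (0.70 log units; beyond the scatter), resting on the step of an at least 4.0-fold higher number from compound 3 to compound 1 (0.60 log units; beyond the scatter) and on the starting number of compound 2 1800 nM. Compound 4 is therefore estimated at 9000 nM, with a range from 4500 nM to 30000 nM, and a real chance that this assay again returns only a limit.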

Compound 4, half-maximal inhibitory concentration: > 10000 nM
Compound 4 gave a limit, no number; the forecaster's own chance of this, stated with the estimate: 45%; at least 1.1-fold (0.04 log units) between middle value and limit.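

In this assay compound 4 gives > 10000 nM, which is a limit of the assay and not a number. Hydroxy in place of hydrogen on a saturated chain carbon bound to two saturated chain carbons weakens inhibition on the core of compound 2 as it does on the core of compound 3, with an at least 5.5-fold higher number from compound 2 to compound 4 (0.74 log units; beyond the scatter), so in this pair of cores the direction of the change carries over from one core to the other: the same change on two cores in this assay, an at least 4.0-fold higher number (0.60 log units; beyond the scatter) from compound 3 to compound 1 and an at least 5.5-fold higher number (0.74 log units; beyond the scatter) from compound 2 to compound 4; the limit leaves it open whether they differ The size of the change does not carry over in any readable way, and two cores are no basis for a rule across the wider series, since both hydroxylated compounds end at the same limit and neither step has an upper bound: the limit of > 10000 nM in this assay, at which 2 of the 4 values shown sit.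

Open, on these data alone, is whether this weakening belongs to the hydroxy group itself or would also follow from a methoxy group, an amine or a carboxylic acid on the same chain carbon. Also open, as far as these compounds go, are the opposite configuration at that carbon, and whether a hydroxy group placed elsewhere on the chain or a shorter chain would leave inhibition measurable as a number.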